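Methoxycarbonyl for aminomethyl on the amine side chain

The source may hold more compounds than are shown below. What is called first, only, known or untested is meant among the compounds shown, and "the series" means these compounds.

Compound 2 `NCCNc1c(C(=O)NCc2ccc(F)cc2)nc(Br)c2cccnc12` holds the only number shown in a functional assay on MDA-MB-435 cells (Homo sapiens) for cytotoxicity, read by MTT assay, with a stated time of 72 h; a higher number here means a weaker inhibitor, a lower number a stronger inhibitor: compound 2 gives 12000 nM. Compound 1 `O=C(NCc1ccc(F)cc1)c1nc(Br)c2cccnc2c1NCc1ccccc1` reaches only a limit of this assay, > 20000 nM. For the measured compounds named here, that limit is the one described as the limit of > 20000 nM in this assay, at which 1 of the 2 values shown sits, and the sole measured step, an at least 1.6-fold lower number from compound 1 to compound 2 (0.22 log units; that floor lies within the scatter), rests on it, so its size has a floor that lies within the scatter.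

Compound 3 `COC(=O)CNc1c(C(=O)NCc2ccc(F)cc2)nc(Br)c2cccnc12` differs from compound 2 in one place: methoxycarbonyl in place of aminomethyl on a saturated chain carbon bound to a nitrogen on an aromatic ring. No measured step compares aminomethyl with methoxycarbonyl; the one step shown, from phenyl to aminomethyl at this same place, is not known to exceed the scatter. Compound 3 is therefore expected to stay near its parent, with the estimated step of a 1.1-fold higher number from compound 2 to compound 3 (0.03 log units; within the scatter). The estimate for compound 3 in this assay is 13000 nM, with a range from 4000 nM to 40000 nM.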

Compound 3, half-maximal inhibitory concentration: 10000 nM
Beside the measured number, compound 3's estimate is 1.3-fold (0.11 log units) above it; low and high end bracket the measured number.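

In this assay, methoxycarbonyl in place of aminomethyl on a saturated chain carbon bound to a nitrogen on an aromatic ring gives a 1.2-fold lower number from compound 2 to compound 3 (0.08 log units; within the scatter), so these two groups do not separate here, although the entering group has 0 hydrogen-bond donors and the leaving group has 1. Methoxycarbonyl in place of phenyl at this same place gives an at least 2.0-fold lower number from compound 1 to compound 3 (0.30 log units; that floor lies within the scatter), so this comparison too does not establish a step beyond the scatter. Compound 1 stands at a limit and not at a number, so the true size of this step stays unknown: the limit of > 20000 nM in this assay, at which 1 of the 3 values shown sits.

On these data alone, whether a carboxylic acid in place of methoxycarbonyl would leave the number where it is remains open. So does whether a longer chain ending in an amine would move it beyond the scatter.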